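Swapping a Chain Nitrile for a Ketone: Solubility Outlook

A few compounds are considered here, and "the series" means these few. Any claim that something is new, unique, unknown or untested is made for them only; others in the source may bear on it.

Measured compounds:
- Compound 1, `Cc1cc(CCC#N)cc(C)c1Oc1cc(Nc2ccc(C#N)cc2)c(N)cc1C(F)(F)F`, gives 0.24 ug/mL in a physicochemical assay for solubility, with a stated time of 4 h, at pH 7.4; on this read-out lower numbers stand for lower solubility and higher numbers for higher solubility.
- Compound 2, `Cc1cc(CCC#N)cc(C)c1Oc1cc(Nc2ccc(C#N)cc2)c(N)cc1C(N)=O`, gives 0.06 ug/mL.
- Compound 3, `COC(=O)c1cc(N)c(Nc2ccc(C#N)cc2)cc1Oc1c(C)cc(CCC#N)cc1C`, gives 1.21 ug/mL.

Compound 1 sits in the middle of these three numbers: going to compound 2 is a 4.0-fold lower number from compound 1 to compound 2 (0.60 log units; beyond the scatter), while going to compound 3 is a 5.0-fold higher number from compound 1 to compound 3 (0.70 log units; beyond the scatter). The widest gap is a 20-fold higher number from compound 2 to compound 3 (1.30 log units; beyond the scatter).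

Compound 4, `CC(=O)CCc1cc(C)c(Oc2cc(Nc3ccc(C#N)cc3)c(N)cc2C(F)(F)F)c(C)c1`, has not been measured. It differs from compound 1 in one place: acetyl in place of cyano on a saturated chain carbon, two bonds along the chain from an aromatic carbon. Every measured step above changes the group on an aromatic carbon, so none of them bears on a change to the saturated chain. The cyano that leaves and the acetyl that enters each carry one hydrogen-bond acceptor and no donor, and the chain grows by one heavy atom. Without a comparable step to lean on, the expected step of a 1.3-fold higher number from compound 1 to compound 4 (0.10 log units; within the scatter) is small, not beyond the scatter, in either direction. Compound 4 is therefore estimated at 0.3 ug/mL, with a range from 0.08 ug/mL to 1.2 ug/mL.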

Compound 4, solubility: 0.16 ug/mL
Compound 4: the middle estimate sits 1.9-fold (0.27 log units) above what was measured, and the stated range covers the measured number.
By their numbers in this assay, from the lowest: compound 2; then compounds 4 and 1 (each within the scatter of the next); then compound 3.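

In this assay, the step is a 1.5-fold lower number from compound 1 to compound 4 (0.18 log units; within the scatter) and so gives no sign that compound 1 and compound 4 differ by more than repeat measurements would. Within the data shown here, this is the first view of the saturated chain, since every earlier step changed a group on an aromatic carbon, and the change from 2-cyanoethyl to 2-acetylethyl does not separate the two compounds. Nothing shown here offers an explanation for this result.

From the compounds shown here alone, whether an amine, a carboxylic acid or a longer chain at this place would give a step beyond the scatter remains open. Going by these compounds, it is also open whether acetyl in place of cyano would give a similar result with methoxycarbonyl or carbamoyl in place of trifluoromethyl on the shared core.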